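From amino to dimethylamino at the assay limit

The source may report more compounds than this note shows. Statements on the series, on what has been measured and on what is new or still open speak of the compounds shown alone.

Compound 1 `O=[N+]([O-])c1cc2cc(c1O)Oc1ccc(cc1)CCc1cccc(O)c1-c1ccc(cc1O)CC2` gives > 20000 nM (a limit)
Compound 2 `Nc1cc2cc(c1O)Oc1ccc(cc1)CCc1cccc(O)c1-c1ccc(cc1O)CC2` gives > 20000 nM (a limit)

In a functional assay on K562 cells (Homo sapiens) for antiproliferative activity, read by MTT assay, with a stated time of 48 h (on this read-out lower numbers stand for stronger inhibition and higher numbers for weaker inhibition), compound 2 gives > 20000 nM as a limit, not a number. Among the compounds with values here, the one other value, for compound 1, is a limit too. Compound 3 `CN(C)c1cc2cc(c1O)Oc1ccc(cc1)CCc1cccc(O)c1-c1ccc(cc1O)CC2` differs from compound 2 in one place: dimethylamino in place of amino on an aromatic carbon, with dimethylamino in place of amino on an aromatic carbon, ortho to a hydroxy group. Within the data shown here, the only measured step that bears on this is a step that the two limits leave unreadable from compound 1 to compound 2, so it offers no size to carry over. The evidence is simply (the limit of > 20000 nM in this assay, at which 2 of the 2 values shown sit), and it shows no measurable activity to build on. No step beyond the scatter is therefore expected in this assay, and no direction can be favoured, so the estimated a number no higher from compound 2 to compound 3 (the limit leaves the size open) is expected to stay small. Compound 3 is estimated at 20000 nM, with an expected range from 7000 nM to 40000 nM, and it may well report only a limit.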

Compound 3, half-maximal inhibitory concentration: > 20000 nM
Compound 3 ended at the assay's limit; the forecaster's own chance of this, stated with the estimate: 70%; the middle value lies on the limit itself.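

No step can be read among compound 1, compound 2 and compound 3, because each result is a limit and not a number: the limit of > 20000 nM in this assay, at which 3 of the 3 values shown sit.

The compounds shown leave open whether any group on this aromatic carbon can give a measurable value in this assay.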